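The compounds below may be only part of what the source reports. "The series", "measured", "known", "first", "only" and "open" are said of these compounds alone.

Compounds measured in a functional assay on aorta with Alpha-1D adrenergic receptor (Rattus norvegicus) as the target; on this read-out higher numbers stand for an effect only at larger amounts of compound and lower numbers for an effect already at smaller amounts:
compound 1 `CSc1ccc(Cc2nn(-c3ccc([N+](=O)[O-])cc3)c(=O)c3ccccc23)cc1`, > 100000 nM
compound 2 `COc1ccc(Cc2nn(C)c(=O)c3ccccc23)cc1`, < 100000 nM
compound 3 `CSc1ccc(Cc2nn(-c3ccc(Br)cc3)c(=O)c3ccccc23)cc1`, > 100000 nM

The value of compound 1 is a limit of this assay. The value of compound 2 is a limit of this assay. The value of compound 3 is likewise a limit of this assay.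

Compound 3 stands at the limit of > 100000 nM in this assay, at which 2 of the 3 values shown sit, together with compound 1; compound 2 alone sits at the limit of < 100000 nM in this assay, at which 1 of the 3 values shown sits. Going by the values given here, the only step between measured compounds, a step that the two limits leave unreadable from compound 1 to compound 3, changes a different position and cannot be read.

Compound 4 `CSc1ccc(Cc2nn(C)c(=O)c3ccccc23)cc1` differs from compound 3 by methyl in place of 4-bromophenyl on an aromatic nitrogen. Among the compounds with values here, no measured step bears directly on this change. Compound 2, which carries the same methyl on the ring nitrogen, sits at the limit of < 100000 nM in this assay, at which 1 of the 3 values shown sits, so compound 4 is expected to fall under the limit as well.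

Compound 4 is estimated at 30000 nM, range 5000 nM to 100000 nM, which means an expected step of an at least 3.3-fold lower number from compound 3 to compound 4 (0.52 log units; beyond the scatter).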

Compound 4, half-maximal effective concentration: 930 nM
Beside the measured number, compound 4's estimate is 32-fold (1.51 log units) above it; measured number outside the range, below it.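

In this assay, going by these compounds alone, the substituent on the aromatic nitrogen gives the first readable change: methyl in place of 4-bromophenyl gives an at least 100-fold lower number from compound 3 to compound 4 (2.03 log units; beyond the scatter), and methyl in place of 4-nitrophenyl gives an at least 100-fold lower number from compound 1 to compound 4 (2.03 log units; beyond the scatter). Compound 1 and compound 3 are limits, so both steps give only a minimum size: the limit of > 100000 nM in this assay, at which 2 of the 4 values shown sit. Compound 2 is also a limit, and the step for methylsulfanyl in place of methoxy cannot be read.

On these data alone, an unsubstituted phenyl, an ethyl or a longer chain on that nitrogen remains open. The methoxy and methylsulfanyl groups therefore remain uncompared.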